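Cyano in place of methoxycarbonyl on the side chain

The source may report more compounds than this note shows. Statements on the series, on what has been measured and on what is new or still open speak of the compounds shown alone.

In a functional assay on T47D cells (Homo sapiens) for cytotoxicity, read by colorimetric assay and MTT assay (on this read-out higher numbers stand for weaker inhibition and lower numbers for stronger inhibition), compound 3 (`COC(=O)CCn1c(=O)c(-c2ccc(OC)cc2)cc2c(OC)cc(OC)cc21`) gives 10000 nM. That matches compound 1 (`COc1ccc(-c2cc3c(OC)cc(OC)cc3n(CCCC#N)c2=O)cc1`) at 10000 nM and compound 2 (`COc1ccc(-c2cc3c(OC)cc(OC)cc3n(CC(=O)OCc3ccccc3)c2=O)cc1`) at 10000 nM, so compound 3 stands level with both. Compound 4 (`COc1ccc(-c2cc3c(OC)cc(OC)cc3n(CCC#N)c2=O)cc1`) carries cyano in place of methoxycarbonyl on a saturated chain carbon, two bonds along the chain from an aromatic nitrogen. The nearest measured change is no change at the digits printed from compound 1 to compound 3 (within the scatter), which also links a nitrile-ending chain to the methoxycarbonyl chain. The other two steps, no change at the digits printed from compound 1 to compound 2 (within the scatter) and no change at the digits printed from compound 2 to compound 3 (within the scatter), show the same picture. The expected step is no change at the digits printed from compound 3 to compound 4 (within the scatter), with nothing beyond the scatter anticipated in this assay. Compound 4 is estimated at 10000 nM, with an expected range of 5000 nM to 20000 nM.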

Compound 4, half-maximal inhibitory concentration: 10000 nM
Beside the measured number, compound 4's estimate shows no gap at the digits printed; the measured number falls inside the stated range.
By their numbers in this assay, from the lowest: compounds 1, 2, 3 and 4 (each within the scatter of the next).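

In this assay, cyano in place of methoxycarbonyl on this chain carbon gives no change at the digits printed from compound 3 to compound 4 (within the scatter), so the two end groups now read alike on a chain of the same length. Cyano in place of cyanomethyl gives no change at the digits printed from compound 1 to compound 4 (within the scatter), and cyanomethyl in place of benzyloxycarbonyl gives no change at the digits printed from compound 2 to compound 4 (within the scatter), which leaves all four side chains level. No supporting data bear on this flat reading. From the compounds shown here alone, whether an amine or a carboxylic acid at the chain end would move the value off this level stays open.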